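This account rests on a few compounds, and the source may have more. Where it says the series, first, only, none or still open, it means among the compounds named here.

Measured compounds:
- compound 1 `CC(=O)Oc1ccccc1C(=O)Oc1ccc(CO[N+](=O)[O-])cc1`: 107000 nM
- compound 2 `CC(=O)Oc1ccc(CCl)cc1`: 8700 nM
- compound 3 `CC(=O)c1ccccc1C(=O)Oc1ccc(CCl)cc1`: 40100 nM

In a functional assay on HT-29 cells (Homo sapiens), with a stated time of 24 h (on this read-out lower numbers stand for an effect already at smaller amounts and higher numbers for an effect only at larger amounts of compound), compound 2 holds the lowest of the three numbers. The nearest of the others is compound 3, whose number lies a step higher that is beyond the scatter; compound 1 lies furthest away, also beyond the scatter. Compound 2 is thus the compound with the effect at the smallest amount among these three.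

Compound 4 `CC(=O)Oc1ccc(CO[N+](=O)[O-])cc1` has not yet been measured in this assay. It differs from compound 2 in one place only: nitrooxy in place of chloro on a saturated chain carbon bound to an aromatic carbon. For the measured compounds named here, no pair of measured compounds isolates this same exchange. Going by the values given here, compound 1 and compound 3 do carry the two groups in question, but they differ from each other in a second place as well, so their values show only that compound 1 gives 107000 nM while compound 3 gives 40100 nM, the nitrooxy-bearing compound at the higher number.

On that basis the step from compound 2 to compound 4 is expected to be upward and of moderate size, a 2.9-fold higher number from compound 2 to compound 4 (0.46 log units; beyond the scatter), likely beyond the scatter in this assay. Compound 4 is accordingly estimated at 25000 nM, within a range from 8000 nM to 80000 nM.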

Compound 4, half-maximal effective concentration: 9300 nM
Compound 4: middle estimate off by 2.7-fold (0.43 log units), on the high side; the range from low to high includes it.
By their numbers in this assay, from the lowest: compounds 2 and 4 (each within the scatter of the next); then compound 3; then compound 1.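

In this assay, nitrooxy in place of chloro on a saturated chain carbon bound to an aromatic carbon reads as a 1.1-fold higher number from compound 2 to compound 4 (0.03 log units; within the scatter), so the two groups cannot be told apart at this position on the core shared by compound 2 and compound 4. For the compounds shown here, this is the first reading of the exchange on its own, since the earlier compounds carried the two groups only together with a second difference. Here one heavy atom leaves and four enter, with hydrogen-bond acceptors added, and the read-out does not separate the pair; nothing at hand explains this result.

As far as these compounds go, compound 1 and compound 3 still differ in a second place, so it remains open whether nitrooxy and chloro also read alike on a core carrying either of their larger ester groups. From the compounds shown here alone, it is equally open whether this position tolerates groups of another kind, such as a hydroxyl, a primary amine or a carboxylic acid on the same carbon, or whether the match holds only for these two groups.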